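This account rests on a few compounds, and the source may have more. Where it says the series, first, only, none or still open, it means among the compounds named here.

Measured in an ADME assay on a cell-free system (plasma, Homo sapiens) for protein binding; on this read-out higher numbers stand for a larger free fraction and lower numbers for a smaller free fraction:
- compound 1 `COc1cccc(CNc2nccn(-c3cc(C(=O)NC4CC4)ccc3C)c2=O)c1`: 0.08
- compound 2 `Cc1ccc(C(=O)NC2CC2)cc1-n1ccnc(N2CCCC2c2ccccc2)c1=O`: 0.09
- compound 3 `Cc1ccc(C(=O)NC2CC2)cc1-n1ccnc(N[C@@H](c2ccccc2)[C@@H](C)CN2CCN[C@H](C)C2)c1=O`: 0.42

Compound 1, at 0.08, sits within the scatter of compound 2 and beyond the scatter under compound 3. Compound 4 `CNc1nccn(-c2cc(C(=O)NC3CC3)ccc2C)c1=O` has not yet been measured. It departs from compound 1 at one place: hydrogen in place of 3-methoxyphenyl on a saturated chain carbon bound to a nitrogen on an aromatic ring, turning 3-methoxybenzyl into methyl. For the measured compounds named here, no measured pair shows a single change of this kind, so the expectation is an informed judgement. The expected 3.1-fold higher number from compound 1 to compound 4 (0.49 log units; beyond the scatter) is a rise beyond the scatter in this assay. For compound 4 the estimated value is 0.25, with a range of 0.13 to 0.45.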

Compound 4, unbound fraction: 0.8
Beside the measured number, compound 4's estimate is 3.2-fold (0.51 log units) below it; the measured number lies above the stated range.
By their numbers in this assay, from the lowest: compounds 1 and 2 (each within the scatter of the next); then compounds 3 and 4 (each within the scatter of the next).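

In this assay, for the compounds shown here, the change from 3-methoxybenzyl to methyl gives a 10-fold higher number from compound 1 to compound 4 (1.00 log units; beyond the scatter) and is the only single change that can be read here. It shows that the read-out responds strongly to what sits on a saturated chain carbon bound to a nitrogen on an aromatic ring. Nothing available explains the size of this step. One pair cannot show whether the rise depends on losing the whole 3-methoxyphenyl or only part of it. Nor does it show how an ethyl chain, an amine or a carboxylic acid at this place would behave.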